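Chloromethyl variants of aminotriazine anilines against dihydrofolate reductase

The compounds below may be only part of what the source reports. "The series", "measured", "known", "first", "only" and "open" are said of these compounds alone.

Measured compounds:
compound 1 `Cc1nc(N)nc(Nc2ccc(Cl)c(Cl)c2)n1` — > 100000 nM (a limit)
compound 2 `Cc1nc(N)nc(Nc2cccc(Br)c2)n1` — > 100000 nM (a limit)
compound 3 `Nc1nc(CCl)nc(Nc2ccc(Cl)c(Cl)c2)n1` — > 100000 nM (a limit)

Three anilino-aminotriazines have been run in an assay for inhibition of Dihydrofolate reductase (Bos taurus), using NADPH; on this read-out lower numbers stand for stronger inhibition and higher numbers for weaker inhibition. Compound 1 reaches only the limit of this assay, > 100000 nM. Compound 2 likewise reaches only the limit, > 100000 nM. Compound 3 again sits at the limit, > 100000 nM. All three values therefore rest on (the limit of > 100000 nM in this assay, at which 3 of the 3 values shown sit), and none is a number.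

Compound 1 and compound 3 differ by chloro in place of hydrogen on a saturated chain carbon bound to an aromatic carbon. The step that the two limits leave unreadable from compound 1 to compound 3 cannot be read, since both ends are limits. The difference between the core of compound 1 and the core of compound 2 is not broken down here.

Compound 4 `Nc1nc(CCl)nc(Nc2cccc(Br)c2)n1` is not yet measured. It differs from compound 2 by chloro in place of hydrogen on a saturated chain carbon bound to an aromatic carbon, the same change as that from compound 1 to compound 3, at the same place. Given that compound 2 shows only the limit > 100000 nM and the same change from compound 1 to compound 3 gave a step that the two limits leave unreadable from compound 1 to compound 3, the step that the limit leaves unreadable from compound 2 to compound 4 is expected to leave compound 4 at the limit as well. Compound 4 is estimated at 150000 nM in this assay, most likely reported again as a limit.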

Compound 4, half-maximal inhibitory concentration: > 100000 nM
Compound 4 ended at the assay's limit; the forecaster's own chance of this, stated with the estimate: 85%; the middle value lies beyond the limit too.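

In this assay compound 4 gives > 100000 nM, which is a limit and not a number. Among the compounds shown here, the methyl to chloromethyl step from compound 2 to compound 4 therefore cannot be read, just as the one from compound 1 to compound 3 could not. The compounds shown leave open whether the chloromethyl change has any effect on inhibition, since every value rests on the same bound: the limit of > 100000 nM in this assay, at which 4 of the 4 values shown sit.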